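Aryl ether series: replacing phenyl with a 1H-pyrazol-4-yl

The source may hold more compounds than are shown below. What is called first, only, known or untested is meant among the compounds shown, and "the series" means these compounds.

Measured so far:
compound 1 `O=c1[nH]c(Oc2ccccc2)nc2cnccc12`, 1.2
compound 2 `O=c1[nH]c(OCC2CCCCC2)nc2cnccc12`, 4.5
compound 3 `O=c1[nH]c(Oc2cccnc2)nc2cnccc12`, -0.2

In a physicochemical assay for lipophilicity, at pH 7.4 (a lower number here means a more polar compound, a higher number a more lipophilic compound), compound 1 gives 1.2, the second highest of the three numbers: its nearest neighbour is compound 3 at -0.2, and compound 2 at 4.5 lies furthest from it. Among the compounds with values here, the one step measured that bears on the next change is a number 1.40 log units lower from compound 1 to compound 3 (beyond the scatter), a large drop.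

Compound 4 `O=c1[nH]c(Oc2cn[nH]c2)nc2cnccc12` differs from compound 1 in one place: 1H-pyrazol-4-yl in place of phenyl on an oxygen on an aromatic ring. As in compound 3, a six-membered ring of carbon only gives way to a heterocycle on the oxygen; here the ring entering is five-membered, carries two hetero atoms and brings one hydrogen-bond donor with one acceptor. Because a number 1.40 log units lower from compound 1 to compound 3 (beyond the scatter) was already large, a step of at least comparable size, downward, is expected in this assay.

For compound 4 the value in this assay is therefore estimated at -0.4, within -1.1 to 0.3, which would mean an expected step of a number 1.60 log units lower from compound 1 to compound 4 (beyond the scatter).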

Compound 4, distribution coefficient: -0.6
Compound 4: the middle estimate sits 0.20 log units above what was measured; the range from low to high includes it.
By their numbers in this assay, from the lowest: compound 4; then compound 3; then compound 1; then compound 2.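

In this assay, a second heterocycle on the oxygen also lowers the number relative to phenyl, here a five-membered ring rather than a six-membered one, with a number 1.80 log units lower from compound 1 to compound 4 (beyond the scatter). The two heterocycles can now be compared directly, and 1H-pyrazol-4-yl in place of pyridin-3-yl gives a number 0.40 log units lower from compound 3 to compound 4 (beyond the scatter), so the identity of the heterocycle still moves the read-out once phenyl has gone, though by much less than leaving phenyl does. No measurement at hand accounts for either step.

Ring size, the hydrogen-bond donor and the hydrogen-bond acceptor all change together between compound 1 and compound 4, so their separate shares in the step remain open. On these data alone, a 1-methyl-1H-pyrazol-4-yl group on the same oxygen would keep the five-membered ring while replacing the ring hydrogen on nitrogen with a methyl, and its reading remains open.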